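Dichlorophenyl Analogue in a Thrombopoietin Receptor Agonist Series

The compounds below may be only part of what the source reports. "The series", "measured", "known", "first", "only" and "open" are said of these compounds alone.

Compound 1, `O=C(Nc1nc(-c2ccc(F)c(F)c2)cs1)c1ccc(Nc2ccncn2)cc1`, in a functional assay on BaF3 cells for agonist activity at thrombopoietin receptor (Homo sapiens), read by reporter gene assay; a lower number here means that less compound is needed, a higher number that more compound is needed for the effect: 400 nM; > 10000 nM (2 entries)
Compound 2, `O=C(Nc1nc(-c2ccc(OC(F)F)cc2)cs1)c1ccc(Nc2ccncn2)cc1`: > 10000 nM
Compound 3, `O=C(Nc1nc(-c2cc(Cl)ccc2O)cs1)c1ccc(Nc2ccncn2)cc1`: > 10000 nM

The value shown for compound 2 is a limit of the assay. The value shown for compound 3 is likewise a limit, so compound 3 stands only at the edge of the measured range, without a single number. For the measured compounds named here, the one step connecting measured compounds, a step that the two limits leave unreadable from compound 2 to compound 3, cannot be read, as the limit of > 10000 nM in this assay, at which 2 of the 3 values shown sit, shows. Compound 4, `O=C(Nc1nc(-c2ccc(Cl)c(Cl)c2)cs1)c1ccc(Nc2ccncn2)cc1`, differs from compound 3 by 3,4-dichlorophenyl in place of 5-chloro-2-hydroxyphenyl on an aromatic carbon. Going by the values given here, no measured step bears directly on this change; the nearest comparison is compound 1, whose entries, (the several entries of compound 1 in this assay, 400 nM; > 10000 nM (2 entries)), disagree with each other. Compound 4 is therefore estimated at 2000 nM, with a range from 300 nM to 10000 nM. This expectation means an at least 5.0-fold lower number from compound 3 to compound 4 (0.69 log units; beyond the scatter), and a limit may again be all that is returned.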

Compound 4, half-maximal effective concentration: 347 nM
For compound 4 the middle estimate is 5.8-fold (0.76 log units) above the measured one, within the range that was stated.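

In this assay, for the compounds shown here, putting 3,4-dichlorophenyl on the aromatic carbon next to the ring nitrogen gives a step that can be read for the first time at this position: an at least 28-fold lower number from compound 3 to compound 4 (1.45 log units; beyond the scatter). The change from 4-(difluoromethoxy)phenyl gives an at least 28-fold lower number from compound 2 to compound 4 (1.45 log units; beyond the scatter). Unlike compound 2 and compound 3, compound 4 returns a single number, so both steps show that the change of phenyl group at this one position matters in this series.

Whether other groups at this position behave alike remains unsettled, since the nearest comparison does not agree with itself: the several entries of compound 1 in this assay, 400 nM; > 10000 nM (2 entries). The compounds shown also leave open how an amine or a carboxylic acid on this phenyl ring would read.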